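Replacing the 3,5-dimethoxyphenyl group of compound 3

The source may hold more compounds than are shown below. What is called first, only, known or untested is meant among the compounds shown, and "the series" means these compounds.

In a functional assay on HepG2 cells (Homo sapiens) for antiproliferative activity, read by MTT assay, with a stated time of 48 h (a higher number here means a weaker inhibitor, a lower number a stronger inhibitor), compound 1 `CCCCc1ccc2c(c1)C(=O)C(=O)N2` reaches only a limit, > 10000 nM. Two relatives of compound 1 give actual numbers in this assay. Compound 2 `COc1ccc(-c2ccc3c(c2)C(=O)C(=O)N3Cc2ccccc2OC)cc1` gives 130 nM, while compound 3 `COc1ccc(CN2C(=O)C(=O)c3cc(-c4cc(OC)cc(OC)c4)ccc32)cc1` gives 1200 nM. Compound 3 therefore has the higher of the two numbers, marking it as the weaker inhibitor by a gap beyond the usual scatter.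

Compound 4 `COc1ccc(CN2C(=O)C(=O)c3cc(-c4ccc(F)c(Cl)c4)ccc32)cc1` has not yet been measured. It differs from compound 3 in one place: 3-chloro-4-fluorophenyl in place of 3,5-dimethoxyphenyl on an aromatic carbon. Here, 3-chloro-4-fluorophenyl stands in place of 3,5-dimethoxyphenyl on an aromatic carbon of the shared core.

Within the data shown here, no measured pair shows this exact swap, so any forecast in this assay must remain loose. The best anchor is compound 3 at 1200 nM, and no shift beyond the scatter is the likeliest outcome, with a slight lean toward a stronger inhibitor. The expected change is a 1.3-fold lower number from compound 3 to compound 4 (0.12 log units; within the scatter). The estimate for compound 4 is 900 nM, with an expected range from 200 nM to 4000 nM.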

Compound 4, half-maximal inhibitory concentration: > 10000 nM
Compound 4: only a limit was reported (the forecaster's own chance of this, stated with the estimate: 8%); middle value at least 11-fold (1.04 log units) away from the limit.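

On an aromatic carbon of the shared core, the choice of phenyl group decides whether a measurable value is obtained at all: in this assay, 3-chloro-4-fluorophenyl in place of 3,5-dimethoxyphenyl gives an at least 8.3-fold higher number from compound 3 to compound 4 (0.92 log units; beyond the scatter). Compound 4 gives > 10000 nM, which is a limit of the assay and not a number. The step is therefore only a minimum, and its true size stays unknown, since the value of compound 4 sits at the end of the measurable range: the limit of > 10000 nM in this assay, at which 2 of the 4 values shown sit.

This single swap removes both methoxy groups and brings in chlorine and fluorine together, so it cannot show which of these changes matters. As far as these compounds go, it also remains open whether a hydroxyl group or an amine on this phenyl ring would give a measurable value.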